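Methoxy on the benzyl ring of a 2-thio-benzothiazole amide

The source may report more compounds than this note shows. Statements on the series, on what has been measured and on what is new or still open speak of the compounds shown alone.

Measured compounds:
compound 1 `CC(=O)Nc1ccc2nc(SCC(=O)NCc3ccccc3)sc2c1`, 17600 nM
compound 2 `COc1ccc(CNC(=O)CSc2nc3ccc(NC(C)=O)cc3s2)cc1`, 20500 nM
compound 3 `O=C(CSc1nc2ccc(NC(=O)c3ccc([N+](=O)[O-])cc3)cc2s1)NCc1ccccc1`, > 100000 nM

In a functional assay on MCF7 cells (Homo sapiens) for cytotoxicity, read by MTT assay, with a stated time of 48 h (on this read-out higher numbers stand for weaker inhibition and lower numbers for stronger inhibition), compound 1 gives 17600 nM and compound 2 gives 20500 nM. Compound 2 differs from compound 1 by methoxy in place of hydrogen on an aromatic carbon. This change brought a 1.2-fold higher number from compound 1 to compound 2 (0.07 log units; within the scatter).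

For compound 3 only a limit is reported in this assay, namely > 100000 nM. Compound 3 differs from compound 1 by 4-nitrophenyl in place of methyl on a carbonyl carbon, and the step is an at least 5.6-fold higher number from compound 1 to compound 3 (0.75 log units; beyond the scatter); its limit is the one noted as the limit of > 100000 nM in this assay, at which 1 of the 3 values shown sits.

Compound 4 `COc1ccc(CNC(=O)CSc2nc3ccc(NC(=O)c4ccc([N+](=O)[O-])cc4)cc3s2)cc1` has not yet been measured. It differs from compound 3 by methoxy in place of hydrogen on an aromatic carbon, the same change as that from compound 1 to compound 2, made at the same kind of place. Since the one measured occurrence of this change, a 1.2-fold higher number from compound 1 to compound 2 (0.07 log units; within the scatter), lay within the scatter, compound 4 is expected to stay at or near the limit of compound 3. In this assay compound 4 is therefore estimated at 150000 nM, between 60000 nM and 400000 nM, a step that the limit leaves unreadable from compound 3 to compound 4.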

Compound 4, half-maximal inhibitory concentration: > 100000 nM
Compound 4 ended at the assay's limit; the forecaster's own chance of this, stated with the estimate: 80%; the middle value lies beyond the limit too.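

In this assay compound 4 is reported only as a limit, > 100000 nM, and the methoxy step from compound 3 to compound 4 therefore cannot be read. The other change, 4-nitrophenyl in place of methyl on a carbonyl carbon, can be read in one direction on the methoxy-bearing pair, an at least 4.8-fold higher number from compound 2 to compound 4 (0.68 log units; beyond the scatter), and it points the same way on both cores: the same change on two cores in this assay, an at least 5.6-fold higher number (0.75 log units; beyond the scatter) from compound 1 to compound 3 and an at least 4.8-fold higher number (0.68 log units; beyond the scatter) from compound 2 to compound 4; the limit leaves it open whether they differ The series thus shows that the direction of this change carries from one core to the other, but it does not show that its size carries over, nor whether methoxy has any effect once 4-nitrophenyl is present: the limit of > 100000 nM in this assay, at which 2 of the 4 values shown sit.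

Going by these compounds, it remains open how methoxy would act on the benzyl ring if the acyl group on the shared core were a plain phenyl or a longer alkyl chain. On these data alone, it also remains open whether a hydroxyl group or an amine in place of the nitro group would bring values that can be read.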